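The source may report more compounds than this note shows. Statements on the series, on what has been measured and on what is new or still open speak of the compounds shown alone.

Compound 1 `CN1CCN(c2ccnc3ccc(-c4cccc(S(N)(=O)=O)c4)nc23)CC1`: 200000 nM
Compound 2 `NS(=O)(=O)c1cccc(-c2ccc3nccc(-c4cn[nH]c4)c3n2)c1`: < 5000 nM, a limit of the assay

Both results come from a physicochemical assay for solubility, read by HPLC, using the shake flask method, measured as kinetic solubility, with a stated time of 20 h, at pH 6.5, tested at 200 uM; a lower number here means a less soluble compound, a higher number a more soluble compound. Compound 2 has no exact number here, only the limit < 5000 nM. Its standing is therefore (the limit of < 5000 nM in this assay, at which 1 of the 2 values shown sits).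

Compound 3 `Cc1ccc(-c2ccnc3ccc(-c4cccc(S(N)(=O)=O)c4)nc23)cn1` carries 6-methylpyridin-3-yl in place of 1H-pyrazol-4-yl on an aromatic carbon, opposite the ring nitrogen (6-methylpyridin-3-yl in place of 1H-pyrazol-4-yl on an aromatic carbon). For the measured compounds named here, one measured step bears on this carbon: an at least 40-fold lower number from compound 1 to compound 2 (1.60 log units; beyond the scatter), a large step beyond the scatter. That step puts 1H-pyrazol-4-yl in place of 4-methylpiperazin-1-yl, so it does not compare one aromatic ring with another. The data hold no direct guide to the new group.

The best anchor is therefore compound 2 at < 5000 nM, and no step beyond the scatter is expected in this assay. Another limit in place of a number would not be surprising. The expected change is a step that the limit leaves unreadable from compound 2 to compound 3. The estimate for compound 3 is 4000 nM, with an expected range from 1000 nM to 25000 nM.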

Compound 3, solubility: < 5000 nM
Compound 3 ended at the assay's limit (the forecaster's own chance of this, stated with the estimate: 60%); the middle value is on the limit's open side.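

Replacing 4-methylpiperazin-1-yl with 6-methylpyridin-3-yl on this aromatic carbon, opposite the ring nitrogen, gives an at least 40-fold lower number from compound 1 to compound 3 (1.60 log units; beyond the scatter) in this assay, a large step beyond the scatter. The large fall thus no longer rests on 1H-pyrazol-4-yl alone: with a five-membered aromatic ring in compound 2 and a six-membered aromatic ring in compound 3, the result is a limit of the assay and not a number. The step between these two compounds cannot be read, because both sit at that limit: the limit of < 5000 nM in this assay, at which 2 of the 3 values shown sit.

Going by these compounds, whether the result of compound 1 needs the whole 4-methylpiperazin-1-yl group, or would also come with a morpholine ring or a plain dimethylamino group at this carbon, stays open. Also open, on these data alone, are the true values of compound 2 and compound 3, and whether a pyridine ring carrying a dimethylaminomethyl group here would rise clear of the limit and give a readable number.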